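A few compounds are considered here, and "the series" means these few. Any claim that something is new, unique, unknown or untested is made for them only; others in the source may bear on it.

Compound 1 `CC(C)c1onc(-c2c(Cl)cccc2Cl)c1COc1ccc(N(C)C(=O)c2ccc(C(=O)O)cc2)c(C(F)(F)F)n1` gives 316 nM in a functional assay on HEK293 cells for agonist activity at Bile acid receptor (Homo sapiens); a lower number here means that less compound is needed, a higher number that more compound is needed for the effect.
Compound 2 `CC(C)c1onc(-c2c(Cl)cccc2Cl)c1COc1ccc(N(C)Cc2cccc(C(=O)O)c2)c(C(F)(F)F)n1` gives 80 nM in this assay.

Among the compounds with values here, compound 2 has the lowest of the two numbers; the only measured step is a 4.0-fold lower number from compound 1 to compound 2 (0.60 log units; beyond the scatter), and it concerns the group on the ring nitrogen, not the five-membered ring. Compound 3 `CN(Cc1cccc(C(=O)O)c1)c1ccc(OCc2c(-c3c(Cl)cccc3Cl)noc2C2CC2)nc1C(F)(F)F` differs from compound 2 by cyclopropyl in place of isopropyl on an aromatic carbon. Within the data shown here, no measured step touches that part of the shared core, so nothing speaks for a shift beyond the scatter; the expected step is no change at the digits printed from compound 2 to compound 3 (within the scatter). For compound 3 in this assay the estimate is 80 nM, with a range of 30 nM to 220 nM.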

Compound 3, half-maximal effective concentration: 9 nM
Compound 3: middle estimate off by 8.9-fold (0.95 log units), on the high side; the whole stated range lies above it.
By their numbers in this assay, from the lowest: compound 3; then compound 2; then compound 1.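

The carbon next to the ring oxygen is not a silent part of the shared core: in this assay, the change from isopropyl to cyclopropyl gives an 8.9-fold lower number from compound 2 to compound 3 (0.95 log units; beyond the scatter). The heavy-atom count stays at 3 carbons and the entering group adds one three-membered ring, so a change this small at this position alone moves the number beyond the scatter. Nothing available accounts for the step.

As far as these compounds go, how cyclobutyl, tert-butyl or ethyl on this carbon would read remains open. So does whether the step holds with the (4-carboxyphenyl)carbonyl group of compound 1 on the nitrogen.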